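Swapping chlorophenyl for trimethoxyphenyl on the benzyl arm

This account rests on a few compounds, and the source may have more. Where it says the series, first, only, none or still open, it means among the compounds named here.

Compound 3 `COc1ccc(-c2nn(-c3ccccc3)cc2C(=O)NCc2cn(Cc3ccc(Cl)cc3)nn2)cc1` gives 26300 nM in a functional assay on MIA PaCa-2 cells (Homo sapiens) for antiproliferative activity, read by sulforhodamine B assay, with a stated time of 48 h (a higher number here means a weaker inhibitor of growth, a lower number a stronger inhibitor of growth), the highest number of the three measured, with compound 2 `COc1ccc(-c2nn(-c3ccccc3)cc2C(=O)NCc2cn(Cc3ccc(F)cc3)nn2)cc1` at 24100 nM and compound 1 `COc1cc(Cn2cc(CNC(=O)c3cn(-c4ccccc4)nc3-c3ccccc3)nn2)cc(OC)c1OC` at 1000 nM. For the measured compounds named here, the only measured one-place step, a 1.1-fold higher number from compound 2 to compound 3 (0.04 log units; within the scatter), swaps one halogen for another and says little about compound 4 `COc1ccc(-c2nn(-c3ccccc3)cc2C(=O)NCc2cn(Cc3cc(OC)c(OC)c(OC)c3)nn2)cc1`, which carries 3,4,5-trimethoxyphenyl in place of 4-chlorophenyl on a saturated chain carbon bound to an aromatic nitrogen. Compound 1 shares that trimethoxyphenyl group but also differs from compound 3 in a second place, so its low number is only a hint. Compound 4 is therefore expected to give a markedly lower number, an estimated step of an 11-fold lower number from compound 3 to compound 4 (1.02 log units; beyond the scatter). The estimate for compound 4 is 2500 nM, between 700 nM and 9000 nM.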

Compound 4, concentration for 50% growth inhibition: 31600 nM
Beside the measured number, compound 4's estimate is 13-fold (1.10 log units) below it; measured number above the stated range.
By their numbers in this assay, from the lowest: compound 1; then compounds 2, 3 and 4 (each within the scatter of the next).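

With the methoxy present on an aromatic carbon, the benzyl arm's substituents hardly separate in this assay: the steps are a 1.2-fold higher number from compound 3 to compound 4 (0.08 log units; within the scatter) and a 1.3-fold higher number from compound 2 to compound 4 (0.12 log units; within the scatter). So 3,4,5-trimethoxyphenyl on a saturated chain carbon bound to an aromatic nitrogen does not set these compounds apart from their halogenated partners. For the compounds shown here, the single change that does is methoxy in place of hydrogen on an aromatic carbon, with a 32-fold higher number from compound 1 to compound 4 (1.50 log units; beyond the scatter), and nothing measured here explains that step.

Still open, from the compounds shown here alone, is whether a hydroxyl or ethoxy in place of that methoxy gives a similarly high number. Also open, going by these compounds, is whether an amine on the benzyl arm would separate from these groups.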